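This account rests on a few compounds, and the source may have more. Where it says the series, first, only, none or still open, it means among the compounds named here.

Compound 2 `CC(C)c1cc([N+](=O)[O-])cc(C(C)C)c1OC(=O)NS(=O)(=O)Oc1c(C(C)C)cccc1C(C)C` stands only at a limit of an assay on liver for inhibition of sterol O-acyltransferase 1 (Rattus norvegicus), using microsomes; on this read-out higher numbers stand for weaker inhibition and lower numbers for stronger inhibition: compound 2 gives > 50000 nM, which is a limit and not a number, as noted in the limit of > 50000 nM in this assay, at which 1 of the 2 values shown sits. For the measured compounds named here, the one measured neighbour is compound 1 `CC(C)c1cc(C(C)(C)C)cc(C(C)C)c1OC(=O)NS(=O)(=O)Oc1c(C(C)C)cccc1C(C)C`, which in this assay gives 8800 nM; the step of an at least 5.6-fold higher number from compound 1 to compound 2 (0.75 log units; beyond the scatter) is the only measured step and is the one that bears on the change considered here. Compound 3 `CC(C)c1cc(Br)cc(C(C)C)c1OC(=O)NS(=O)(=O)Oc1c(C(C)C)cccc1C(C)C` carries bromo in place of nitro on an aromatic carbon. The bromo group is neither the nitro of compound 2 nor the tert-butyl of compound 1, so compound 3 is expected to fall between them, nearer the number of compound 1 than the limit of compound 2, while a limit cannot be ruled out. The expected step is an at least 2.5-fold lower number from compound 2 to compound 3 (0.39 log units; beyond the scatter). Compound 3 is estimated at 20000 nM, with a range from 6000 nM to 60000 nM.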

Compound 3, half-maximal inhibitory concentration: 31000 nM
The estimate for compound 3 lay 1.6-fold (0.19 log units) below the measured number; measured number inside the range.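

In this assay, bromo gives this position, para to a large group, a second group with a true number, so the loss from tert-butyl can now be sized: a 3.5-fold higher number from compound 1 to compound 3 (0.55 log units; beyond the scatter). Against nitro the picture is less firm, with an at least 1.6-fold lower number from compound 2 to compound 3 (0.20 log units; that floor lies within the scatter), so bromo and nitro are not clearly separated and no order between them can be claimed. The value of compound 2 remains a limit and not a number: the limit of > 50000 nM in this assay, at which 1 of the 3 values shown sits.

From the compounds shown here alone, whether an amine, a methoxy group or a longer alkyl chain at this position would give a lower number than compound 1 stays open. Also open, going by these compounds, is whether the step from tert-butyl to bromo would hold with a different group on the other side of the shared core.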